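The compounds below may be only part of what the source reports. "The series", "measured", "known", "first", "only" and "open" are said of these compounds alone.

In this assay a functional assay on HeLa cells (Homo sapiens) for antiproliferative activity, with a stated time of 24 h (on this read-out higher numbers stand for weaker inhibition and lower numbers for stronger inhibition), the measured compounds are:
compound 1 `Cc1ccccc1CN1CCc2c(sc(NC(=O)c3ccccc3Cl)c2C(N)=O)C1` gives > 50000 nM, a limit of the assay.
compound 2 `NC(=O)c1c(NC(=O)c2ccc(C(F)(F)F)cc2)sc2c1CCN(Cc1c(Cl)cccc1Cl)C2` gives > 50000 nM, also a limit of the assay.
compound 3 `NC(=O)c1c(NC(=O)c2cccc([N+](=O)[O-])c2)sc2c1CCN(Cc1ccc(Cl)cc1Cl)C2` gives 33000 nM.

Compound 1 therefore stands at a limit rather than at a number; (the limit of > 50000 nM in this assay, at which 2 of the 3 values shown sit). Within the data shown here, compound 3 is the only compound with a number, and that number lies close to the limit. Compound 4 `NC(=O)c1c(NC(=O)c2ccccc2Cl)sc2c1CCN(C(=S)Nc1ccccc1I)C2` has not yet been measured in this assay. The change from compound 1 to compound 4 is the following.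
a group of 10 heavy atoms (7 carbon, 1 nitrogen, 1 sulfur, 1 iodine; one six-membered aromatic ring of carbon only) in place of a group of 8 heavy atoms (8 carbon; one six-membered aromatic ring of carbon only), on an amine nitrogen in a ring
Among the measured compounds shown here, no step between measured compounds is available, so the size of this change cannot be read from the data. Because compound 1 sits at the limit of > 50000 nM in this assay, at which 2 of the 3 values shown sit, the step of a number no higher from compound 1 to compound 4 (the limit leaves the size open) is expected to be none beyond the scatter, with a further limit the most likely outcome. For compound 4 the expected value is 50000 nM, with a range from 10000 nM to 150000 nM.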

Compound 4, half-maximal inhibitory concentration: 29000 nM
Beside the measured number, compound 4's estimate is 1.7-fold (0.24 log units) above it; the measured number falls inside the stated range.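

Compound 1 stands at a limit of the assay, > 50000 nM. With the group carrying sulfur and iodine in place of 2-methylbenzyl on the amine nitrogen in a ring, compound 4 gives a number in this assay, 29000 nM, so a change at this position alone can yield a reading rather than a limit. The data show an at least 1.7-fold lower number from compound 1 to compound 4 (0.23 log units; that floor lies within the scatter), and its true size stays open because compound 1 has no number: the limit of > 50000 nM in this assay, at which 2 of the 4 values shown sit.

The compounds shown leave open whether the sulfur or the iodine matters here. Going by these compounds, a urea or an unsubstituted phenyl at this position remains untested among them.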